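The compounds below may be only part of what the source reports. "The series", "measured", "known", "first", "only" and "open" are said of these compounds alone.

In a functional assay on the whole organism for antagonist activity, with Mus musculus as the target, in the maximal electroshock model (on this read-out higher numbers stand for an effect only at larger amounts of compound and lower numbers for an effect already at smaller amounts), two compounds sharing one core have been measured so far. Compound 1 `COC(=O)NC1=NC(c2ccccc2F)CN1`, which carries a fluoro group on its aromatic ring, gives 54 mg/kg. Compound 2 `COC(=O)NC1=NC(c2ccccc2Cl)CN1`, with a chloro group instead, gives 50 mg/kg, which places it level with compound 1 within the usual scatter of such measurements. Compound 3 `COC(=O)NC1=NC(c2ccccc2Br)CN1` has not yet been measured in this assay. It differs from compound 2 by bromo in place of chloro on an aromatic carbon. Among the compounds with values here, the one measured step that bears on this change, chloro in place of fluoro, is a 1.1-fold lower number from compound 1 to compound 2 (0.03 log units; within the scatter), so no step beyond the scatter is expected in either direction. The estimated step is a 1.0-fold lower number from compound 2 to compound 3 (0.02 log units; within the scatter). Compound 3 is expected to give 48 mg/kg, with an estimated range of 28 mg/kg to 82 mg/kg.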

Compound 3, dose for half-maximal effect: 62 mg/kg
The estimate for compound 3 lay 1.3-fold (0.11 log units) below the measured number; the range from low to high includes it.
By their numbers in this assay, from the lowest: compounds 2, 1 and 3 (each within the scatter of the next).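

In this assay, bromo in place of chloro gives a 1.2-fold higher number from compound 2 to compound 3 (0.09 log units; within the scatter) and bromo in place of fluoro gives a 1.1-fold higher number from compound 1 to compound 3 (0.06 log units; within the scatter) on this aromatic carbon, which is ortho to a large group. The earlier pair showed only that fluoro and chloro could be exchanged here without a step beyond the scatter; bromo now joins them, so all three compounds stand level on this read-out and the exchange of one of these groups for another shows no measurable effect. Nothing measured here explains why these three groups give such similar numbers.

Still open, going by these compounds, is whether a group of a different kind on this carbon, such as methoxy, an amine or a carboxylic acid, would produce a step beyond the scatter. The compounds shown also leave open whether fluoro, chloro and bromo would stay level on another carbon of the same ring.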